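A few compounds are considered here, and "the series" means these few. Any claim that something is new, unique, unknown or untested is made for them only; others in the source may bear on it.

Of the compounds shown here, three built on a shared core have been measured so far. Compound 1 `ClCc1cccc(Cn2cnc3c(Cl)nc(Cl)nc32)c1`, compound 2 `ClCc1cccc(Cn2cnc3nc(Cl)nc(Cl)c32)c1` and compound 3 `ClCc1ccc(Cn2cnc3c(Cl)nc(Cl)nc32)cc1` were each tested in a functional assay on HOP-62 cells (Homo sapiens) for cytotoxicity, read by sulforhodamine B assay, with a stated time of 48 h; on this read-out higher numbers stand for weaker inhibition of growth and lower numbers for stronger inhibition of growth. Compound 1 gives 4360 nM, compound 2 gives 3630 nM, and compound 3 gives 5130 nM. Compound 2 has the lowest of the three numbers, but its gaps to compound 1 and to compound 3 both lie within the scatter, so the three values are best read as alike. Among the compounds with values here, no pair of measured compounds differing in a single place is available here, so no measured step can be drawn on.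

Compound 4 `ClCc1cccc(Cn2cnc3ncnc(Cl)c32)c1` has not yet been measured. It differs from compound 2 by hydrogen in place of chloro on an aromatic carbon. All three measured compounds carry two chloro groups on the core, so nothing measured shows what removing one does. The step of a 1.7-fold higher number from compound 2 to compound 4 (0.22 log units; within the scatter) is expected to be small, toward a higher number, at about the edge of the scatter. Compound 4 is therefore expected to give about 6000 nM in this assay, with a range from 2500 nM to 15000 nM.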

Compound 4, concentration for total growth inhibition: 3980 nM
For compound 4 the middle estimate is 1.5-fold (0.18 log units) above the measured one; the measured number falls inside the stated range.
By their numbers in this assay, from the lowest: compounds 2, 4, 1 and 3 (each within the scatter of the next).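

In this assay, putting hydrogen in place of the chloro group between two ring nitrogen atoms gives a 1.1-fold higher number from compound 2 to compound 4 (0.04 log units; within the scatter) and so leaves no difference that can be told apart from the scatter. Within the data shown here, this is the first comparison here between two compounds that differ in one place, and it shows that growth inhibition at this level does not depend on having chloro on this aromatic carbon. Nothing measured here bears on why the two compounds read alike.

On these data alone, it remains open whether a different group on this carbon, such as an amine or a methoxy group, would move the number beyond the scatter. Also open, as far as these compounds go, is whether the remaining chloro group matters, since compound 2 and compound 4 both carry it.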